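Nitro for hydrogen on the aromatic ring: compound 3

The compounds below may be only part of what the source reports. "The series", "measured", "known", "first", "only" and "open" are said of these compounds alone.

Of the compounds shown here, two have been measured in an assay on isolated protein for binding affinity to Adrenergic receptor alpha-1 (Rattus norvegicus), read by radioligand binding; on this read-out higher numbers stand for weaker inhibition and lower numbers for stronger inhibition. Compound 1 `O=C1C2CCCN2C(=O)N1CN1CCN(c2cccc(Cl)c2)CC1` gives 292 nM. Compound 2 `O=C1C2CCCCN2C(=O)N1CN1CCN(c2ccccc2)CC1` returns no number in this assay, only a limit, > 1000 nM. That limit is the point at which compound 2 stands, as recorded in the limit of > 1000 nM in this assay, at which 1 of the 2 values shown sits. Among the measured compounds shown here, compound 1 and compound 2 differ in two places, so no single step joins them; their two values show only that compound 1 sits with a measured number while compound 2 sits at the limit.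

Compound 3 `O=C1C2CCCCN2C(=O)N1CN1CCN(c2ccc([N+](=O)[O-])cc2)CC1` has not yet been measured. It derives from compound 2 by nitro in place of hydrogen on an aromatic carbon. For the measured compounds named here, no measured pair in the set shows this change, so nothing anchors its size or direction. Compound 2 itself offers only the limit > 1000 nM as a starting point. For compound 3 the step that the limit leaves unreadable from compound 2 to compound 3 is expected to stay within the scatter, with no clear direction. Compound 3 is therefore estimated at 1500 nM, with a range from 400 nM to 6000 nM, and a further limit reading is quite possible.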

Compound 3, inhibition constant: > 10000 nM
Compound 3: no number, only a limit (the forecaster's own chance of this, stated with the estimate: 55%); at least 6.6-fold (0.82 log units) between middle value and limit.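

In this assay compound 3 gives only a limit (> 10000 nM), and compound 2 likewise gives only a limit (> 1000 nM), so the step between these two compounds cannot be read. The compounds shown leave open how large the effect of going from phenyl to 4-nitrophenyl is on binding affinity, and in which direction it runs.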